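Removing a methoxy group from the aryl ring of compound 3

The source may hold more compounds than are shown below. What is called first, only, known or untested is meant among the compounds shown, and "the series" means these compounds.

Compound 3 `COc1cc(C(=O)/C=C/c2cc(-c3cc(OC)c(OC)c(OC)c3)n[nH]2)cc(OC)c1OC` stands together with compound 2 `COc1ccc(C(=O)/C=C/c2cc(-c3cc(OC)c(OC)c(OC)c3)n[nH]2)cc1` at the top of the three numbers: in a functional assay on K562 cells (Homo sapiens) for cytotoxicity, read by sulforhodamine B assay, with a stated time of 48 h, tested at 100 uM (a lower number here means a stronger effect, a higher number a weaker effect of the compound at the concentration tested), compound 3 gives 1% and compound 2 gives 1%, no difference at the digits shown, while compound 1 `COc1ccc(C(=O)/C=C/c2cc(-c3cc(OC)c(OC)c(OC)c3)n[nH]2)cc1OC` gives -15%, a number 16 percentage points higher from compound 1 to compound 3 (beyond the scatter) and a number 16 percentage points higher from compound 1 to compound 2 (beyond the scatter). Compound 4 `COc1ccc(-c2cc(/C=C/C(=O)c3cc(OC)c(OC)c(OC)c3)[nH]n2)cc1OC` differs from compound 3 by hydrogen in place of methoxy on an aromatic carbon. The same kind of change, hydrogen in place of methoxy on an aromatic carbon, appears once among the measured pairs, a number 16 percentage points higher from compound 1 to compound 2 (beyond the scatter), a modest rise. The two measured steps suggest a small upward step at most, possibly none beyond the scatter. Compound 4 is therefore expected to show a number 5 percentage points higher from compound 3 to compound 4 (within the scatter), with an estimated value of 6%, between -10% and 22%.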

Compound 4, a percentage reported as activity, at one concentration (the size of the read-out at that concentration, not a potency): -16%
For compound 4 the middle estimate is 22 percentage points above the measured one, outside the stated range (below it).
By their numbers in this assay, from the lowest: compounds 4 and 1 (each within the scatter of the next); then compounds 2 and 3 (each within the scatter of the next).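

In this assay, hydrogen in place of methoxy on an aromatic carbon gives a number 17 percentage points lower from compound 3 to compound 4 (beyond the scatter), so this change lowers the number here. The earlier pair had shown only a rise, and the direction of the change now proves to differ with the core that carries it: the same change on two cores in this assay, a number 16 percentage points higher (beyond the scatter) from compound 1 to compound 2 and a number 17 percentage points lower (beyond the scatter) from compound 3 to compound 4, 33 percentage points apart, beyond the scatter of two such steps

The compounds shown leave open how an amine or a hydroxyl group on this aromatic carbon would read against the methoxy group of compound 3 and the hydrogen of compound 4. Among the compounds shown here, with a read-out at one concentration, they also give no potency for either compound.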